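Amide series notes: a second chloro added to compound 2

This account rests on a few compounds, and the source may have more. Where it says the series, first, only, none or still open, it means among the compounds named here.

compound 1 `CCc1ccc(C(=O)Nc2ccc3nc(N4CCN(CC)CC4)cc(C)c3c2)cc1` — 3060 nM in a functional assay on MCF7 cells (Homo sapiens) for antiproliferative activity, read by MTT assay, with a stated time of 72 h; on this read-out higher numbers stand for weaker inhibition and lower numbers for stronger inhibition
compound 2 `CCN1CCN(c2cc(C)c3cc(NC(=O)c4ccc(Cl)cc4)ccc3n2)CC1` — 1530 nM
compound 3 `Cc1cc(N2CCN(C(C)C)CC2)nc2ccc(NC(=O)c3ccc(Cl)c(Cl)c3)cc12` — 1710 nM

Within the data shown here, compound 2 holds the lowest of the three numbers in this assay, but all three values lie within the scatter of one another; the one single-place step, a 2.0-fold lower number from compound 1 to compound 2 (0.30 log units; within the scatter), is itself within the scatter. Compound 4 `CCN1CCN(c2cc(C)c3cc(NC(=O)c4ccc(Cl)c(Cl)c4)ccc3n2)CC1` differs from compound 2 by chloro in place of hydrogen on an aromatic carbon. Among the measured compounds shown here, no measured step matches this change. Compound 3 carries the same 3,4-dichlorophenyl group and its value sits within the scatter of compound 2, yet it also differs at the piperazine substituent, so it is only an indirect hint. The expected step is a 1.0-fold lower number from compound 2 to compound 4 (0.01 log units; within the scatter), nothing beyond the scatter. Compound 4 is estimated at 1500 nM, with a range from 600 nM to 4000 nM.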

Compound 4, half-maximal inhibitory concentration: 1380 nM
Beside the measured number, compound 4's estimate is 1.1-fold (0.04 log units) above it, within the range that was stated.
By their numbers in this assay, from the lowest: compounds 4, 2, 3 and 1 (each within the scatter of the next, the first and the last beyond it).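

In this assay taking 4-chlorophenyl to 3,4-dichlorophenyl gives a 1.1-fold lower number from compound 2 to compound 4 (0.04 log units; within the scatter) and so a chloro placed ortho to a chloro group and meta to a large group leaves the number within the scatter. With the 3,4-dichlorophenyl group held, hydrogen in place of methyl on the saturated chain carbon bound to the ring amine nitrogen gives a 1.2-fold lower number from compound 3 to compound 4 (0.09 log units; within the scatter) and is equally unresolved. Only 3,4-dichlorophenyl in place of 4-ethylphenyl gives a 2.2-fold lower number from compound 1 to compound 4 (0.35 log units; beyond the scatter) and so passes the scatter, though modestly.

Going by these compounds, whether an amine or a carboxylic acid in place of the added chloro would shift the number stays open. No measurement at hand accounts for any of these steps.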